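Exchange of the piperidine substituent in the amide series

This account rests on a few compounds, and the source may have more. Where it says the series, first, only, none or still open, it means among the compounds named here.

Compound 3 `Cc1ccc(CC2CCN(c3nc(C(F)(F)F)ccc3CNC(=O)C(C)c3ccc(NS(C)(=O)=O)c(F)c3)CC2)cc1` gives 17 nM in a functional assay on CHO-K1 cells for antagonist activity at transient receptor potential cation channel subfamily V member 1 (Homo sapiens), read by FLIPR; on this read-out higher numbers stand for weaker inhibition and lower numbers for stronger inhibition. Among the compounds with values here, on the numbers so far it lies in the middle of three: compound 1 `CC(C(=O)NCc1ccc(C(F)(F)F)nc1N1CC=CCC1)c1ccc(NS(C)(=O)=O)c(F)c1` gives 12.1 nM and compound 2 `CC(C(=O)NCc1ccc(C(F)(F)F)nc1N1CCC(c2ccccc2)CC1)c1ccc(NS(C)(=O)=O)c(F)c1` gives 25 nM, and both gaps to compound 3 are within the scatter. Compound 4 `CC(=O)OC1CCN(c2nc(C(F)(F)F)ccc2CNC(=O)C(C)c2ccc(NS(C)(=O)=O)c(F)c2)CC1` carries acetoxy in place of 4-methylbenzyl on a saturated ring carbon. Within the data shown here, no measured step removes an aryl group from the saturated ring, so the bearing is indirect. The step of a 2.1-fold higher number from compound 1 to compound 2 (0.32 log units; beyond the scatter) shows that attaching phenyl to this ring position carries a modest cost, and the step of a 1.5-fold lower number from compound 2 to compound 3 (0.17 log units; within the scatter) shows that enlarging phenyl to 4-methylbenzyl changes little. Among the measured compounds shown here, compound 4 drops the aryl group altogether and puts a small oxygen-bearing group in its place, which has no precedent here; the most that can be read is that losing the aryl need not be harmful. For compound 4 the expected change is a 1.2-fold higher number from compound 3 to compound 4 (0.07 log units; within the scatter), that is, nothing beyond the scatter, with wide uncertainty. The estimate for compound 4 is 20 nM, within 7 nM to 60 nM.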

Compound 4, half-maximal inhibitory concentration: 139 nM
Compound 4: the middle estimate sits 7.0-fold (0.84 log units) below what was measured; the whole stated range lies below it.
By their numbers in this assay, from the lowest: compounds 1, 3 and 2 (each within the scatter of the next, the first and the last beyond it); then compound 4.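

Acetoxy is not tolerated on this saturated ring carbon as the aryl-bearing groups are: in place of 4-methylbenzyl it gives an 8.2-fold higher number from compound 3 to compound 4 (0.91 log units; beyond the scatter) and in place of phenyl it gives a 5.6-fold higher number from compound 2 to compound 4 (0.75 log units; beyond the scatter) on the same ring, whereas the two aryl-bearing compounds stand within the scatter of each other. Within the data shown here, measured against the smaller ring group of the series, the change gives an 11-fold higher number from compound 1 to compound 4 (1.06 log units; beyond the scatter) and is the only large step so far, which leaves compound 4 the weakest of the four in this assay and shows that this position does not accept every substituent. Nothing at hand explains this loss.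

The compounds shown leave open whether the loss goes with the acetoxy group itself or with the absence of an aromatic ring on this carbon. A hydroxyl, an amine, a carboxylic acid or a plain alkyl chain here would help to separate the two.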